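Working notes: substituent exchange from compound 3 to compound 4

The source may report more compounds than this note shows. Statements on the series, on what has been measured and on what is new or still open speak of the compounds shown alone.

Measured compounds:
compound 1, `N=C(NCc1ccccc1)[C@@H]1CCC(=O)N1Cc1ccccc1`: 16.6%
compound 2, `N=C(NCc1ccccc1)[C@@H]1CCC(=O)N1Cc1ccc([N+](=O)[O-])cc1`: 13.7%
compound 3, `N=C(NCc1ccccc1)[C@@H]1CCC(=O)N1Cc1ccc(F)cc1`: 13.3%

In a functional assay on SH-SY5Y cells (Homo sapiens) for cytotoxicity, read by MTT assay, with stated times of 8 h, 30 min and 12 h, tested at 0.05 uM (on this read-out lower numbers stand for a weaker effect and higher numbers for a stronger effect at the one concentration tested), compound 3 gives 13.3%. Its two measured steps, a number 3.3 percentage points lower from compound 1 to compound 3 (within the scatter) and a number 0.4 percentage points lower from compound 2 to compound 3 (within the scatter), both stay within the scatter, and the remaining pair, a number 2.9 percentage points lower from compound 1 to compound 2 (within the scatter), does as well, so the three numbers cannot be ordered against one another; compound 3 sits among them, not apart from them.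

Compound 4, `COc1ccc(CN2C(=O)CC[C@H]2C(=N)NCc2ccccc2)cc1`, differs from compound 3 in one place: methoxy in place of fluoro on an aromatic carbon. The same ring position has already been varied three ways, hydrogen, nitro and fluoro, and each of those exchanges left this assay unchanged beyond the scatter. For the measured compounds named here, none of the measured steps involves methoxy, so the closest guide is that the ring position has so far been insensitive to what sits on it.

On that basis compound 4 is expected to read close to compound 3, with an estimated step of a number 1.2 percentage points higher from compound 3 to compound 4 (within the scatter), a movement within the scatter and in no particular direction. The estimated value for compound 4 in this assay is 14.5%, with a range from 9% to 20%.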

Compound 4, a percentage reported as activity, at one concentration (the size of the read-out at that concentration, not a potency): 12.3%
For compound 4 the middle estimate is 2.2 percentage points above the measured one; low and high end bracket the measured number.
By their numbers in this assay, from the lowest: compounds 4, 3, 2 and 1 (each within the scatter of the next).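

Methoxy is a fourth substituent on an aromatic carbon of a six-membered aromatic ring of carbon only, para to a large group, and in this assay the three new steps, a number 1 percentage points lower from compound 3 to compound 4 (within the scatter) and a number 1.4 percentage points lower from compound 2 to compound 4 (within the scatter) and a number 4.3 percentage points lower from compound 1 to compound 4 (within the scatter) all stay within the scatter. The exchange of 4-fluorophenyl for 4-methoxyphenyl changes the heavy-atom and hydrogen-bond-acceptor counts of the substituent, yet hydrogen, nitro, fluoro and methoxy still cannot be ordered against one another on this read-out, so the insensitivity seen among the first three compounds now extends to a group containing oxygen and carbon. No separate data bear on the reason for this result.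

These compounds leave open whether an amine, a carboxylic acid or a longer chain such as butoxy in the same place would also remain within the scatter of compounds 1 to 4. They also leave open whether changes elsewhere on the shared core would move this read-out, and how these compounds would compare at other concentrations.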